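Replacing the Acid of Compound 1 with a Hydroxyethyl Amide

The source may hold more compounds than are shown below. What is called first, only, known or untested is meant among the compounds shown, and "the series" means these compounds.

The three measured compounds share one core and differ only in the group on a carbonyl carbon of a short side chain. In a functional assay on the whole organism (strain Wistar) for inhibition, with Rattus norvegicus as the target, read by paw edema, with stated times of 60 min and 4 h, at a dose of 100 mg/kg by the oral route (a higher number here means more inhibition at the dose given (going by the name of the read-out), a lower number less inhibition), compound 1 `COc1cc2c(cc1OC)C(CC(=O)O)CC2` gives 23.9%, the lowest of the three numbers. Compound 2 `COc1cc2c(cc1OC)C(CC(=O)N(C)C)CC2` gives 35.9%, and compound 3 `COc1cc2c(cc1OC)C(CC(=O)NC(C)C)CC2` gives 39.1%.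

Two steps start from compound 1: a number 12 percentage points higher from compound 1 to compound 2 (beyond the scatter) and a number 15.2 percentage points higher from compound 1 to compound 3 (beyond the scatter). Between the two amide-bearing compounds the gap is small, a number 3.2 percentage points higher from compound 2 to compound 3 (within the scatter), so both changes away from the free acid land in roughly the same place.

Compound 4 `COc1cc2c(cc1OC)C(CC(=O)NCCO)CC2` is the not yet measured member. Its difference from compound 1 is (2-hydroxyethyl)amino in place of hydroxy on a carbonyl carbon, which again replaces the acid at the carbonyl carbon by a nitrogen-linked group, here one that carries an extra hydroxy on a two-carbon chain.

Both measured steps from compound 1 to a nitrogen-bearing group were modest rises, so a rise of similar size is expected here rather than no change. The expected step is a number 13.1 percentage points higher from compound 1 to compound 4 (beyond the scatter). For compound 4 the estimated value in this assay is 37%, with a range from 25% to 49%.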

Compound 4, a percentage reported as inhibition, in the whole organism at one dose (the size of the read-out at that dose, not a potency): 9.37%
The estimate for compound 4 lay 27.6 percentage points above the measured number, outside the stated range (below it).
By their numbers in this assay, from the lowest: compound 4; then compound 1; then compounds 2 and 3 (each within the scatter of the next).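

The nitrogen-linked group on the carbonyl carbon does not by itself raise the number in this assay: with (2-hydroxyethyl)amino in place of hydroxy, the result is a number 14.5 percentage points lower from compound 1 to compound 4 (beyond the scatter) and the direction is the opposite of the rises seen with the dimethylamino and isopropylamino groups. The groups on the amide nitrogen also turn out to matter at this position, with a number 26.5 percentage points lower from compound 2 to compound 4 (beyond the scatter) and a number 29.7 percentage points lower from compound 3 to compound 4 (beyond the scatter) even though compound 2 and compound 3 stay within the scatter of each other. No other measurement accompanies these numbers, so the data offer no explanation for this reversal.

The compounds shown leave open whether the drop goes with the terminal hydroxy or with the two-carbon chain that carries it, which a plain ethylamino group or a 2-methoxyethyl group on the amide nitrogen would help to separate. They also leave open how the length of the chain bears on the result, as a 3-hydroxypropyl group would show.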